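Ester extension in a dihydropyridine series

A few compounds are considered here, and "the series" means these few. Any claim that something is new, unique, unknown or untested is made for them only; others in the source may bear on it.

Measured compounds:
Compound 1, `COC(=O)C1=C(C)NC(C)=C(C(=O)OC)C1c1cnc(SC)n1Nc1ccccc1`: 3.54 nM
Compound 2, `CSc1ncc(C2C(C(=O)OC(C)C)=C(C)NC(C)=C2C(=O)OC(C)C)n1Nc1ccccc1`: 2.16 nM
Compound 3, `CSc1ncc(C2C(C(=O)OCc3ccccc3)=C(C)NC(C)=C2C(=O)OCc2ccccc2)n1Nc1ccccc1`: 1.49 nM

Three compounds share one core and differ only in their ester groups. In an assay on isolated protein (strain albino) for antagonist activity at Voltage-dependent L-type calcium channel subunit alpha-1C (Cavia porcellus) (a lower number here means a stronger inhibitor, a higher number a weaker inhibitor), compound 1 gives 3.54 nM, the highest of the three numbers. Compound 2 gives 2.16 nM, a value that lies within the scatter of compound 1. Compound 3 gives 1.49 nM, and the gap between compound 1 and compound 3 lies beyond the scatter. Taken together the two larger esters sit at or below compound 1, but no single step between them is given, so no general trend is claimed.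

The unmeasured compound 4, `COCCOC(=O)C1=C(C)NC(C)=C(C(=O)OC)C1c1cnc(SC)n1Nc1ccccc1`, is reached from compound 1 by methoxymethyl in place of hydrogen on a saturated chain carbon bound to an oxygen next to a carbonyl group. One ester of compound 1 is thus lengthened to a 2-methoxyethyl ester, while the other ester stays as it is.

Going by the values given here, no measured pair shows this exact change. Given that compound 2 and compound 3, with larger esters, give numbers at or below compound 1, compound 4 is expected to show at most a modest lowering from compound 1, with the step of a 1.4-fold lower number from compound 1 to compound 4 (0.15 log units; within the scatter) estimated to fall near the edge of the scatter. For compound 4 in this assay the expected value is 2.5 nM, within a range from 1 nM to 6 nM.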

Compound 4, half-maximal inhibitory concentration: 9.65 nM
For compound 4 the middle estimate is 3.9-fold (0.59 log units) below the measured one; the measured number lies above the stated range.
By their numbers in this assay, from the lowest: compounds 3, 2 and 1 (each within the scatter of the next, the first and the last beyond it); then compound 4.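

In this assay, going by these compounds alone, the single change from methoxycarbonyl to (2-methoxyethoxy)carbonyl on one ester gives a 2.7-fold higher number from compound 1 to compound 4 (0.44 log units; beyond the scatter) and so a weaker inhibitor. Within the data shown here, this is the first comparison that isolates one ester, since compound 2 and compound 3 differ from compound 1 at both esters and their numbers cannot be assigned to either place alone. It shows that this position does respond to extension, and that adding methoxymethyl on the saturated chain carbon bound to the ester oxygen costs inhibition, even though the two larger symmetrical esters gave no such loss. Nothing available gives a cause for this step.

The compounds shown leave open whether the loss follows from the added chain length or from the ether oxygen, which a plain butyl ester on the same position would help to separate. They also leave open how a terminal amine or a carboxylic acid on this chain would read, and whether the 2-methoxyethyl ester would give a similar step if it stood on both sides of the shared core.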